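From Cyclopentylamino to Methoxy on a Shared Core

The compounds below may be only part of what the source reports. "The series", "measured", "known", "first", "only" and "open" are said of these compounds alone.

In a functional assay on HeLa cells (Homo sapiens) for antiproliferative activity, read by WST assay, with a stated time of 24 h (on this read-out higher numbers stand for weaker inhibition and lower numbers for stronger inhibition), compound 1 `C=C[C@]1(C)CC[C@@H](C(=C)CNC(C)C)C[C@H]1C(=C)C` gives 40 nM as its reading, while compound 2 `C=C[C@]1(C)CC[C@@H](C(=C)CNC2CCCC2)C[C@H]1C(=C)C` gives 520 nM as the higher of the two numbers, which makes compound 2 the weaker inhibitor of the pair. Compound 3 `C=C[C@]1(C)CC[C@@H](C(=C)COC)C[C@H]1C(=C)C` is the next structure to be measured. The change is methoxy in place of cyclopentylamino on a saturated chain carbon bound to a double-bonded chain carbon, with methoxy in place of cyclopentylamino on a saturated chain carbon bound to a double-bonded chain carbon. Going by the values given here, only one measured step bears on this site: cyclopentyl in place of isopropyl on an amine nitrogen gave a 13-fold higher number from compound 1 to compound 2 (1.11 log units; beyond the scatter), a large change. Among the compounds with values here, no measured compound lacks that nitrogen, so this step offers only indirect guidance. Even so, a change of the whole group could plausibly shift the reading in this assay beyond the scatter, more likely towards a higher number, though by less than the measured step. The estimated change is a 3.8-fold higher number from compound 2 to compound 3 (0.59 log units; beyond the scatter), and its direction remains uncertain. Compound 3 is expected to read about 2000 nM, with an estimated range from 250 nM to 15000 nM.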

Compound 3, half-maximal inhibitory concentration: 212000 nM
For compound 3 the middle estimate is 110-fold (2.03 log units) below the measured one, and the stated range ends below it.
By their numbers in this assay, from the lowest: compound 1; then compound 2; then compound 3.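

At the saturated chain carbon bound to a double-bonded chain carbon, methoxy in place of cyclopentylamino gives a 410-fold higher number from compound 2 to compound 3 (2.61 log units; beyond the scatter) in this assay, and methoxy in place of isopropylamino gives a 5300-fold higher number from compound 1 to compound 3 (3.72 log units; beyond the scatter). Both steps are larger than the only earlier one, a 13-fold higher number from compound 1 to compound 2 (1.11 log units; beyond the scatter), so among these three compounds, replacing the whole amino group moves the reading further than changing the substituent on its nitrogen, and the two compounds that carry the nitrogen both read lower than the one that lacks it. Nothing measured here accounts for the size of this shift.

The change from cyclopentylamino to methoxy alters the nitrogen, the ring and the hydrogen-bond donor count all at once, so these compounds do not separate the contribution of each. Going by these compounds, it remains open whether an unsubstituted amino group, a hydroxyl or an ethoxy group at this place would read closer to compound 1 or to compound 3, and whether a tertiary amine such as dimethylamino would keep the lower readings of the two secondary amines.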